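A few compounds are considered here, and "the series" means these few. Any claim that something is new, unique, unknown or untested is made for them only; others in the source may bear on it.

Measured in a functional assay on PC-3 cells (Homo sapiens) for inhibition, read by MTT assay; on this read-out higher numbers stand for weaker inhibition and lower numbers for stronger inhibition:
- compound 1 `COc1c(N2CCN(C)CC2)c(F)cc2c(=O)c(C(=O)N/N=C\c3ccc([N+](=O)[O-])cc3)cn(C3CC3)c12`: 15 ug/mL
- compound 2 `COc1c(N2CCN(C)CC2)c(F)cc2c(=O)c(C(=O)N/N=C\c3ccc(O)cc3)cn(C3CC3)c12`: 14.4 ug/mL

Among the measured compounds shown here, compound 2, at 14.4 ug/mL, stands level with compound 1, since the only measured step, a 1.0-fold lower number from compound 1 to compound 2 (0.02 log units; within the scatter), is within the scatter. Compound 3 `COc1ccc(OC)c(/C=N\NC(=O)c2cn(C3CC3)c3c(OC)c(N4CCN(C)CC4)c(F)cc3c2=O)c1` follows from compound 2 through one change: 2,5-dimethoxyphenyl in place of 4-hydroxyphenyl on a carbon with a double bond to nitrogen. For the measured compounds named here, the one measured step, hydroxy in place of nitro on an aromatic carbon, is a different swap, so it offers only thin guidance. Still, with nothing else to go on, no shift beyond the scatter is expected in this assay. The expected change is a 1.0-fold lower number from compound 2 to compound 3 (0.01 log units; within the scatter). For compound 3 the estimated value is 14 ug/mL, with an expected range of 7 ug/mL to 28 ug/mL.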

Compound 3, half-maximal inhibitory concentration: 3 ug/mL
The estimate for compound 3 lay 4.7-fold (0.67 log units) above the measured number; the measured number lies below the stated range.
By their numbers in this assay, from the lowest: compound 3; then compounds 2 and 1 (each within the scatter of the next).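

In this assay, the group on the carbon with a double bond to nitrogen can clearly change the result: 2,5-dimethoxyphenyl gives stronger inhibition, with a 4.8-fold lower number from compound 2 to compound 3 (0.68 log units; beyond the scatter) and, against the 4-nitrophenyl compound, a 5.0-fold lower number from compound 1 to compound 3 (0.70 log units; beyond the scatter). Swapping hydroxy for nitro had moved nothing beyond the scatter, so this is the first change here to shift the number. Nothing available explains the shift.

Still open, going by these compounds, is whether one methoxy alone would do the same, or whether both are needed. An amine or a carboxylic acid on the same ring could also behave differently.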